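Fluoro for Methoxy on a Second Core: Solubility Outlook

The source may hold more compounds than are shown below. What is called first, only, known or untested is meant among the compounds shown, and "the series" means these compounds.

Of the compounds shown here, three of one series have been measured in a physicochemical assay for solubility, at pH 7.4; on this read-out lower numbers stand for lower solubility and higher numbers for higher solubility. Compound 1 `O=C(NCCCCN1CCCCC1)Nc1ccc(-c2ccccc2F)cc1` gives 95000 nM in this assay. Compound 3 `COc1ccccc1-c1ccc(NC(=O)NCCCCN2CCCCC2)cc1` gives 114000 nM. Compound 2 `COc1ccccc1-c1ccc(NC(=O)NCCCCN2CCCCC2)cn1` gives 174000 nM, the highest of the three numbers, though its gaps to compound 3 and to compound 1 both lie within the scatter, so no ordering among them can be claimed.

Compound 3 and compound 1 share a core and differ in one place: fluoro in place of methoxy on an aromatic carbon. This change made a step of a 1.2-fold lower number from compound 3 to compound 1 (0.08 log units; within the scatter), which lies within the scatter.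

Compound 2 carries a different core; the difference between the two cores is not broken down here. The unmeasured compound 4 `O=C(NCCCCN1CCCCC1)Nc1ccc(-c2ccccc2F)nc1` is related to compound 2 by the same change: fluoro in place of methoxy on an aromatic carbon. The place of the change is the same in both pairs, so the change is the same in kind.

Going by the values given here, with only one earlier instance of this change, which left the number within the scatter, the step from compound 2 to compound 4 in this assay is expected to be of similar size, a 1.2-fold lower number from compound 2 to compound 4 (0.08 log units; within the scatter), because compound 3 to compound 1 gave a 1.2-fold lower number from compound 3 to compound 1 (0.08 log units; within the scatter). Compound 4 is therefore estimated at 145000 nM in this assay, with a plausible range from 70000 nM to 300000 nM, resting on compound 2 at 174000 nM.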

Compound 4, solubility: 196000 nM
For compound 4 the middle estimate is 1.4-fold (0.13 log units) below the measured one; low and high end bracket the measured number.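

In this assay the swap of methoxy for fluoro on the core of compound 2 gave a 1.1-fold higher number from compound 2 to compound 4 (0.05 log units; within the scatter) and thus stayed within the scatter, as it did on the other core, where the same change gave a 1.2-fold lower number from compound 3 to compound 1 (0.08 log units; within the scatter) in the earlier pair. So in the two pairs shown, the change from 2-methoxyphenyl to 2-fluorophenyl carried from one core to the other without a step beyond the scatter, but the opposite directions printed for the two steps carry no meaning at this size, and two pairs do not show that the change would stay this small on any further core. Nothing in the material on hand accounts for the size of either step.

Going by these compounds, it remains open whether a chloro, a nitrile or a carboxylic acid at the same place on the aromatic ring would also leave the number within the scatter on both cores. Going by these compounds alone, it is equally open whether the two steps would stay this small if a longer chain took the place of the one these compounds share, or if a primary amine took the place of the piperidine at its end.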